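Swapping bromo for iodo: compound 2 to compound 3

The source may report more compounds than this note shows. Statements on the series, on what has been measured and on what is new or still open speak of the compounds shown alone.

In an ADME assay on PBMC cells (Homo sapiens) for cytotoxicity, with a stated time of 5 days (a lower number here means a stronger inhibitor, a higher number a weaker inhibitor), compound 1 `Cc1ccsc1C(=O)/C=C/c1ccc(N2CCCCC2)cc1` gives 26400 nM.
Compound 2 `O=C(/C=C/c1ccc(N2CCCCC2)cc1)c1ccc(Br)s1` reaches only a limit of this assay, > 100000 nM.

Compound 2 therefore stands at the limit of > 100000 nM in this assay, at which 1 of the 2 values shown sits, rather than at a number. Among the measured compounds shown here, the one measured step, an at least 3.7-fold higher number from compound 1 to compound 2 (0.57 log units; beyond the scatter), bears on it only as the change that led to this limit. Compound 3 `O=C(/C=C/c1ccc(N2CCCCC2)cc1)c1ccc(I)s1` differs from compound 2 by iodo in place of bromo on an aromatic carbon. For the measured compounds named here, no measured step swaps one halogen for another, so no direction beyond the scatter is expected. Compound 3 is estimated at 100000 nM, with a range from 30000 nM to 300000 nM, and the expected step is a number no higher from compound 2 to compound 3 (the limit leaves the size open).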

Compound 3, half-maximal inhibitory concentration: > 100000 nM
Compound 3 gave a limit, no number; the forecaster's own chance of this, stated with the estimate: 60%; the middle value lies on the limit itself.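

With 5-iodothiophen-2-yl on the carbonyl carbon, this assay again ends at a limit rather than a number, so iodo joins bromo at this place: the limit of > 100000 nM in this assay, at which 2 of the 3 values shown sit. The step between the two halogen compounds cannot be read, and bromo and iodo cannot be ordered here. Replacing 3-methylthiophen-2-yl with 5-iodothiophen-2-yl gives an at least 3.7-fold higher number from compound 1 to compound 3 (0.57 log units; beyond the scatter), the same direction as with bromo.

Going by these compounds, what chloro or an amine would give at this place stays open. Also open, on these data alone, is whether the halogen or the loss of the 3-methyl group carries this step, as the two change together.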